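The step from compound 3 to compound 4

The compounds below may be only part of what the source reports. "The series", "measured", "known", "first", "only" and "open" are said of these compounds alone.

Compound 1 (`COc1cc2nnc(C(N)=O)c(Nc3ccc(C)cc3F)c2cc1N1CCN(S(C)(=O)=O)CC1`): 1.7 L/kg
Compound 2 (`COc1cc2nnc(C(N)=O)c(Nc3ccc(C)cc3F)c2cc1N1C[C@@H](C)N[C@@H](C)C1`): 1.6 L/kg
Compound 3 (`COc1cc2nnc(C(N)=O)c(Nc3ccc(C)cc3F)c2cc1N1CCC(N(C)C)CC1`): 2.2 L/kg

These three values come from an ADME assay on the whole organism for pharmacokinetics, with Rattus norvegicus as the target (on this read-out higher numbers stand for wider distribution into tissues and lower numbers for narrower distribution), and differ only in the group on one aromatic carbon of the shared core. Compound 3 stands within the scatter of both other compounds (a 1.3-fold higher number from compound 1 to compound 3 (0.11 log units; within the scatter); a 1.4-fold higher number from compound 2 to compound 3 (0.14 log units; within the scatter)). The remaining pair behaves alike (a 1.1-fold lower number from compound 1 to compound 2 (0.03 log units; within the scatter)).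

Compound 4 (`COc1cc2nnc(C(N)=O)c(Nc3ccc(C)cc3F)c2cc1N1CCN(C(C)C)CC1`) has not yet been measured. It carries 4-isopropylpiperazin-1-yl in place of the 4-(dimethylamino)piperidin-1-yl of compound 3 (4-isopropylpiperazin-1-yl in place of 4-(dimethylamino)piperidin-1-yl on an aromatic carbon). Within the data shown here, no measured step makes this exact exchange, but all three steps at this place stayed within the scatter, including the step to compound 3 from compound 1 (a 1.3-fold higher number from compound 1 to compound 3 (0.11 log units; within the scatter)). Going by these compounds, no shift beyond the scatter is therefore expected in this assay for this exchange, and the direction remains open. The expected step (a 1.1-fold lower number from compound 3 to compound 4 (0.04 log units; within the scatter)) is estimated to stay within the scatter. Compound 4 is estimated at 2 L/kg (expected range 1.2 L/kg to 3.4 L/kg).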

Compound 4, volume of distribution at steady state: 3.8 L/kg
The estimate for compound 4 lay 1.9-fold (0.28 log units) below the measured number; measured number outside the range, above it.
By their numbers in this assay, from the lowest: compounds 2, 1, 3 and 4 (each within the scatter of the next, the first and the last beyond it).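

In this assay, among these compounds, this position had so far given only steps within the scatter, and compound 4 supplies the first ones beyond it, both modest (a 2.4-fold higher number from compound 2 to compound 4 (0.38 log units; beyond the scatter); a 2.2-fold higher number from compound 1 to compound 4 (0.35 log units; beyond the scatter)). Moving the same atoms from 4-(dimethylamino)piperidin-1-yl to 4-isopropylpiperazin-1-yl still stays within the scatter (a 1.7-fold higher number from compound 3 to compound 4 (0.24 log units; within the scatter)), so only compound 4, and not compound 3, stands clear of both compound 1 and compound 2. No measurement available here accounts for this result.

The compounds shown leave open whether isopropyl is special on that ring amine nitrogen, since a cyclopropyl group, a tert-butyl group or a longer chain there has no number in this set. They also leave open how a morpholin-4-yl ring at the same aromatic carbon would compare.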